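Replacing a Fused Bicyclic Amide Substituent with Pyridine

This account rests on a few compounds, and the source may have more. Where it says the series, first, only, none or still open, it means among the compounds named here.

Compound 1, `COc1cccc(C(=O)Nc2cc3cnc(NCCN(C)C)cc3n(C)c2=O)c1`, gives 17400 nM in a functional assay on MDA-MB-468 cells (Homo sapiens) for antiproliferative activity, read by MTT assay, with a stated time of 48 h; on this read-out higher numbers stand for weaker inhibition and lower numbers for stronger inhibition.
Compound 2, `CN(C)CCNc1cc2c(cn1)cc(NC(=O)c1cc3ccccc3s1)c(=O)n2C`, gives 3570 nM in this assay.
Compound 3, `CN(C)CCNc1cc2c(cn1)cc(NC(=O)c1ccccc1)c(=O)n2C`, gives 18300 nM in this assay.

All three compounds share one core and differ only in the group attached to the amide carbonyl. Compound 2, which carries the 1-benzothiophen-2-yl group, stands lowest of the three numbers, and since both of its steps to the other compounds lie beyond the scatter, it is the most potent of the measured set. The untested compound 4, `CN(C)CCNc1cc2c(cn1)cc(NC(=O)c1ccncc1)c(=O)n2C`, differs from compound 2 in one place: pyridin-4-yl in place of 1-benzothiophen-2-yl on a carbonyl carbon.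

Among the measured compounds shown here, two measured steps bear on this change. Going from a single six-membered carbon ring to the fused bicyclic group lowered the number, a 4.9-fold lower number from compound 1 to compound 2 (0.69 log units; beyond the scatter), and the reverse exchange raised it, a 5.1-fold higher number from compound 2 to compound 3 (0.71 log units; beyond the scatter). Removing the methoxy made almost no difference, a 1.1-fold higher number from compound 1 to compound 3 (0.02 log units; within the scatter), so the single-ring compounds cluster together. Compound 4 carries a single six-membered ring, so a step back up toward those compounds is expected: a 4.2-fold higher number from compound 2 to compound 4 (0.62 log units; beyond the scatter). Compound 4 is therefore estimated at 15000 nM, with a range from 6000 nM to 40000 nM.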

Compound 4, half-maximal inhibitory concentration: 8360 nM
Compound 4: middle estimate off by 1.8-fold (0.25 log units), on the high side; the measured number falls inside the stated range.
By their numbers in this assay, from the lowest: compound 2; then compound 4; then compounds 1 and 3 (each within the scatter of the next).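

The earlier compounds shown here suggested that a single six-membered ring on the amide carbonyl simply gives numbers like those of compounds 1 and 3, but in this assay pyridin-4-yl stands apart from both, with a 2.2-fold lower number from compound 3 to compound 4 (0.34 log units; beyond the scatter) and a 2.1-fold lower number from compound 1 to compound 4 (0.32 log units; beyond the scatter) as its two steps. Phenyl and pyridin-4-yl differ only by a nitrogen in place of one ring carbon, so a change within the ring itself moves the number at this position, whereas removing the methoxy group did not. The fused group still gives the lowest number, with a 2.3-fold higher number from compound 2 to compound 4 (0.37 log units; beyond the scatter) on leaving it, so compound 2 remains the most potent of the four, though a single ring no longer means the full loss seen with phenyl.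

Nothing shown here gives a reason for these differences. As far as these compounds go, it remains open whether the placement of the nitrogen matters, as pyridin-3-yl or pyridin-2-yl would show, and whether a nitrogen also helps in a fused group such as quinolin-2-yl.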